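Methoxyphenyl variant of compound 2: outlook

A few compounds are considered here, and "the series" means these few. Any claim that something is new, unique, unknown or untested is made for them only; others in the source may bear on it.

Within the data shown here, compound 2 `Fc1ccc(-c2cn3ccnc3c(-c3ccc4ncn(C5CCCCC5)c4c3)n2)cc1` gives 3.5% in a functional assay on LOX IMVI cells (Homo sapiens) for inhibition, read by sulforhodamine B assay, with a stated time of 48 h, tested at 10 uM (on this read-out lower numbers stand for less inhibition and higher numbers for more inhibition at the one concentration tested (going by the name of the read-out)), the lowest of the two numbers measured so far; compound 1 `O=Cc1ccc(-c2cn3ccnc3c(-c3ccc4ncn(C5CCCCC5)c4c3)n2)cc1` gives 46.9%. Among the measured compounds shown here, the only measured step, a number 43.4 percentage points lower from compound 1 to compound 2 (beyond the scatter), changes the same aryl group and shows that a change there can shift the read-out strongly. Compound 3 `COc1ccccc1-c1cn2ccnc2c(-c2ccc3ncn(C4CCCCC4)c3c2)n1` carries 2-methoxyphenyl in place of 4-fluorophenyl on an aromatic carbon. For the measured compounds named here, no measured pair covers a methoxy group, so that step is the only guide, and it points both ways. A moderate rise is expected, a number 16.5 percentage points higher from compound 2 to compound 3 (beyond the scatter), with wide uncertainty. Compound 3 is estimated at 20%, between 0% and 50%.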

Compound 3, a percentage reported as inhibition, at one concentration (the size of the read-out at that concentration, not a potency): 5.13%
For compound 3 the middle estimate is 14.9 percentage points above the measured one; low and high end bracket the measured number.
By their numbers in this assay, from the lowest: compounds 2 and 3 (each within the scatter of the next); then compound 1.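

In this assay the step of a number 1.6 percentage points higher from compound 2 to compound 3 (within the scatter) shows that 2-methoxyphenyl and 4-fluorophenyl do not separate at this position, even though only the former carries a methoxy group. Among these compounds, the step of a number 41.8 percentage points lower from compound 1 to compound 3 (beyond the scatter) leaves 4-formylphenyl as the only group among the three that stands apart from the others. Nothing at hand explains this pattern.

Still open, as far as these compounds go, is whether the formyl group itself matters or any similar group would serve. A carboxylic acid or an aminomethyl group in its place would test this.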